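This account rests on a few compounds, and the source may have more. Where it says the series, first, only, none or still open, it means among the compounds named here.

Compound 1 `Cc1ccc(NC(=O)/C=C/c2ccccc2)c(C(N)=O)c1` and compound 2 `NC(=O)c1cc(Br)ccc1NC(=O)/C=C/c1ccccc1` share one core and differ in a single place. In a functional assay on NCI/ADR-RES cells (Homo sapiens) for inhibition, read by sulforhodamine B assay, with a stated time of 48 h (a lower number here means a stronger inhibitor of growth, a higher number a weaker inhibitor of growth), compound 1 gives 2790 nM, and compound 2 gives 400 nM, so a 7.0-fold lower number from compound 1 to compound 2 (0.84 log units; beyond the scatter). As far as these compounds go, compound 3 `NC(=O)c1cc(I)ccc1NC(=O)/C=C/c1ccccc1` carries iodo where compound 2 carries bromo, but in this assay compound 3 gives "not determined" (no result reported), so its standing is unknown. Compound 4 `NC(=O)c1cc(I)ccc1NC(=O)/C=C/c1ccccc1Cl` differs from compound 3 by chloro in place of hydrogen on an aromatic carbon. Going by the values given here, no measured step touches the phenyl of the cinnamoyl part, so the only known step, from compound 1 to compound 2, does not bear on this change, and no shift beyond the scatter is expected in this assay. Taking compounds 1 and 2 as the only anchors, compound 4 is estimated at 700 nM, with a range from 150 nM to 3500 nM.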

Compound 4, concentration for 50% growth inhibition: 719 nM
Estimate against measurement, compound 4: 1.0-fold (0.01 log units) below, and the stated range covers the measured number.
By their numbers in this assay, from the lowest: compounds 2 and 4 (each within the scatter of the next); then compound 1.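

Compound 3 gives no number to compare with, so the change from compound 3 to compound 4 cannot be read as a step. As far as these compounds go, what phenyl to 2-chlorophenyl does alone, and how iodo compares with bromo, stays open. Nothing shown offers a cause for these results.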